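Replacing the nitro group of compound 3 with acetamido

A few compounds are considered here, and "the series" means these few. Any claim that something is new, unique, unknown or untested is made for them only; others in the source may bear on it.

In a functional assay on QGY-7703 cells (Homo sapiens) for cytotoxicity, read by MTT assay, with a stated time of 24 h (a lower number here means a stronger inhibitor, a higher number a weaker inhibitor), compound 1 (`CN1C/C(=C\c2cccnc2)C(=O)/C(=C/c2ccccc2C(F)(F)F)C1`) gives 2910 nM, compound 2 (`O=C1/C(=C/c2cccnc2)CN(S(=O)(=O)c2ccccc2)C/C1=C\c1ccccc1C(F)(F)F`) gives 6240 nM and compound 3 (`O=C1/C(=C/c2cccnc2)CN(S(=O)(=O)c2ccc([N+](=O)[O-])cc2)C/C1=C\c1ccccc1C(F)(F)F`) gives 7660 nM. Compound 3 lies within the scatter of compound 2, and both show higher numbers than compound 1. Compound 4 (`CC(=O)Nc1ccc(S(=O)(=O)N2C/C(=C\c3cccnc3)C(=O)/C(=C/c3ccccc3C(F)(F)F)C2)cc1`) has acetamido in place of nitro on an aromatic carbon, para to a large group: acetamido in place of nitro on an aromatic carbon. The closest measured change, a 1.2-fold higher number from compound 2 to compound 3 (0.09 log units; within the scatter), put nitro in place of hydrogen on that carbon. The modest steps of a 2.1-fold higher number from compound 1 to compound 2 (0.33 log units; beyond the scatter) and a 2.6-fold higher number from compound 1 to compound 3 (0.42 log units; beyond the scatter) instead changed the group on the amine nitrogen in a ring. Among the measured compounds shown here, no measured compound carries acetamido, so no step beyond the scatter is expected. The estimated change is a 1.2-fold lower number from compound 3 to compound 4 (0.07 log units; within the scatter). For compound 4 the estimate is 6500 nM, with an expected range from 3500 nM to 12000 nM.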

Compound 4, half-maximal inhibitory concentration: 5380 nM
Compound 4: the middle estimate sits 1.2-fold (0.08 log units) above what was measured, and the stated range covers the measured number.
By their numbers in this assay, from the lowest: compounds 1, 4, 2 and 3 (each within the scatter of the next, the first and the last beyond it).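

In this assay acetamido on the aromatic carbon para to a large group stays within the scatter of both nitro (a 1.4-fold lower number from compound 3 to compound 4 (0.15 log units; within the scatter)) and hydrogen (a 1.2-fold lower number from compound 2 to compound 4 (0.06 log units; within the scatter)). Where the earlier compounds compared only hydrogen and nitro here, three groups at this carbon now give numbers within the scatter of one another. No evidence is available on why this carbon responds so little. The compounds shown leave open whether an amine or a carboxylic acid at this carbon would give a step beyond the scatter. They also leave open whether acetamido on another carbon of that aromatic ring would read the same.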